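The source may report more compounds than this note shows. Statements on the series, on what has been measured and on what is new or still open speak of the compounds shown alone.

Measured so far:
- compound 1, `Cc1cn([C@@H]2O[C@H](CO[Si](C)(C)C(C)(C)C)[C@@]3(OS(=O)(=O)C=C3NCC(=O)O)[C@H]2O[Si](C)(C)C(C)(C)C)c(=O)n(C)c1=O`: 300000 nM
- compound 2, `Cc1cn([C@@H]2O[C@H](CO[Si](C)(C)C(C)(C)C)[C@@]3(OS(=O)(=O)C=C3NCC(=O)C(=O)O)[C@H]2O[Si](C)(C)C(C)(C)C)c(=O)n(C)c1=O`: 400000 nM
- compound 3, `Cc1cn([C@@H]2O[C@H](CO[Si](C)(C)C(C)(C)C)[C@@]3(OS(=O)(=O)C=C3NCCC(=O)O)[C@H]2O[Si](C)(C)C(C)(C)C)c(=O)n(C)c1=O`: 80000 nM

In a functional assay on HEL cells (Homo sapiens) for cytotoxicity, read by microscopy (on this read-out lower numbers stand for higher toxicity in this test and higher numbers for lower toxicity in this test), compound 3 gives the lowest of the three numbers, its nearest neighbour being compound 1. The next compound, compound 4 with the structure `Cc1cn([C@@H]2O[C@H](CO[Si](C)(C)C(C)(C)C)[C@@]3(OS(=O)(=O)C=C3NCC(=O)C(N)=O)[C@H]2O[Si](C)(C)C(C)(C)C)c(=O)n(C)c1=O`, differs from compound 3 as follows: carbamoylcarbonyl in place of carboxymethyl on a saturated chain carbon bound to an amine nitrogen. Within the data shown here, two measured steps bear on this. The step of a 5.0-fold lower number from compound 2 to compound 3 (0.70 log units; beyond the scatter) shows that moving away from a carboxycarbonyl chain lowered the number modestly, and the step of a 1.3-fold higher number from compound 1 to compound 2 (0.12 log units; within the scatter) shows that lengthening the chain by a carbonyl stayed within the scatter. Among the measured compounds shown here, compound 4 returns to a carbonyl-containing chain, so a modest rise back toward the numbers of compound 1 and compound 2 is expected, a 3.8-fold higher number from compound 3 to compound 4 (0.57 log units; beyond the scatter), with no measured step covering the carboxy-to-carbamoyl exchange itself. Compound 4 is therefore estimated at 300000 nM, between 100000 nM and 900000 nM.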

Compound 4, minimum cytotoxic concentration: >= 16000 nM
Compound 4 was reported as a limit; the forecaster's own chance of this, stated with the estimate: 15%; the middle value is on the limit's open side.
By their numbers in this assay, from the lowest: compound 3; then compounds 1 and 2 (each within the scatter of the next).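

In this assay compound 4 gives >= 16000 nM, which is a limit and not a number, so its steps from compound 1, compound 2 and compound 3 cannot be read. The compounds shown leave open where compound 4 stands among these three.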